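Replacing the ester with an amide in a urea series

This account rests on a few compounds, and the source may have more. Where it says the series, first, only, none or still open, it means among the compounds named here.

Of the compounds shown here, three have been measured in a functional assay on A375P cells (Homo sapiens) for cytotoxicity, read by MTT assay; a lower number here means a stronger inhibitor, a higher number a weaker inhibitor. Compound 1 `COC(=O)c1ccc2c(ccn2-c2ccc(NC(=O)c3ccc(Cl)c(C(F)(F)F)c3)cc2)n1` gives 3000 nM. Compound 2 `COC(=O)c1ccc2c(ccn2-c2ccc(NC(=O)Nc3ccc(Cl)c(Cl)c3)cc2)n1` gives 3800 nM; the two cores differ only at the carbonyl, where ((3,4-dichlorophenyl)amino in place of 4-chloro-3-(trifluoromethyl)phenyl on a carbonyl carbon), and the step of a 1.3-fold higher number from compound 1 to compound 2 (0.10 log units; within the scatter) lies within the scatter. Compound 3 `NC(=O)c1ccc2c(ccn2-c2ccc(NC(=O)c3ccc(Cl)c(C(F)(F)F)c3)cc2)n1` gives 8900 nM. It differs from compound 1 by amino in place of methoxy on a carbonyl carbon, and that change produced the step of a 3.0-fold higher number from compound 1 to compound 3 (0.47 log units; beyond the scatter).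

Compound 4 `NC(=O)c1ccc2c(ccn2-c2ccc(NC(=O)Nc3ccc(Cl)c(Cl)c3)cc2)n1` has not yet been measured. It stands to compound 2 as compound 3 stands to compound 1: the difference is amino in place of methoxy on a carbonyl carbon. The place is described in the same words for both pairs, so this is the same change on a different core, and among the four compounds it occurs twice. Within the data shown here, the only guide to its size is the one measured instance, the step from compound 1 to compound 3, which weakened the inhibitor by a modest but clear amount. If the same change on the core of compound 2 behaves alike, the expected step from compound 2 to compound 4 in this assay is a 2.9-fold higher number from compound 2 to compound 4 (0.46 log units; beyond the scatter), resting on a 3.0-fold higher number from compound 1 to compound 3 (0.47 log units; beyond the scatter). The starting point is the value of compound 2, 3800 nM. Compound 4 is therefore expected to give about 11000 nM, with a likely range from 5000 nM to 25000 nM.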

Compound 4, half-maximal inhibitory concentration: 3200 nM
Beside the measured number, compound 4's estimate is 3.4-fold (0.54 log units) above it; measured number below the stated range.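

In this assay, putting amino in place of methoxy on the carbonyl carbon gave a 1.2-fold lower number from compound 2 to compound 4 (0.07 log units; within the scatter), so on this core the change has no effect that can be told apart from the ordinary spread of repeated measurements. The same change therefore does not carry over in size from one core to the other, and the two measured instances differ by more than that spread: the same change on two cores in this assay, a 3.0-fold higher number (0.47 log units; beyond the scatter) from compound 1 to compound 3 and a 1.2-fold lower number (0.07 log units; within the scatter) from compound 2 to compound 4, 3.5-fold (0.55 log units) apart, beyond the scatter of two such steps. This shows that the weakening seen on the core of compound 1 is not a fixed cost of replacing methoxycarbonyl with carbamoyl, but two instances cannot show which difference between the cores decides the outcome, or how the change would behave on a third core.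

The compounds shown leave open how other groups on this carbonyl carbon, such as a carboxylic acid, a methylamide or an ethyl ester, would behave on either core. They also leave open whether those groups would track the result on the core of compound 1, the result on the core of compound 2, or neither.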